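Halogen exchange on the arylsulfanylmethyl side chain

This account rests on a few compounds, and the source may have more. Where it says the series, first, only, none or still open, it means among the compounds named here.

Two compounds of the shared core carry measured numbers. Compound 1 `OC[C@H]1O[C@@H](n2cnc3c(SC4CCCCC4)ncnc32)[C@H](O)[C@@H]1O` gives 6310 nM in an assay on isolated protein for binding affinity to Equilibrative nucleoside transporter 1 (Homo sapiens); a higher number here means a weaker inhibitor, a lower number a stronger inhibitor. Within the data shown here, compound 2 `OC[C@H]1O[C@@H](n2cnc3c(CSc4ccccc4Cl)ncnc32)[C@H](O)[C@@H]1O` gives 1780 nM in this assay; the step of a 3.5-fold lower number from compound 1 to compound 2 (0.55 log units; beyond the scatter) places compound 2 at the lowest number of the two, with compound 1 as its only neighbour. Compound 3 `OC[C@H]1O[C@@H](n2cnc3c(CSc4ccccc4F)ncnc32)[C@H](O)[C@@H]1O` is the next member; it differs from compound 2 by fluoro in place of chloro on an aromatic carbon. Among the measured compounds shown here, no measured step covers a halogen exchange: the only step, a 3.5-fold lower number from compound 1 to compound 2 (0.55 log units; beyond the scatter), swaps a cyclohexylsulfanyl group for a ((2-chlorophenyl)sulfanyl)methyl group, a far larger change than the one in hand, and gives no direct guide to a chloro-to-fluoro exchange. The expected step of a 1.4-fold higher number from compound 2 to compound 3 (0.15 log units; within the scatter) in this assay is therefore small, most likely within the scatter, with a slight lean toward a higher number. For compound 3 the estimate in this assay is 2500 nM, within 1000 nM to 6300 nM.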

Compound 3, half-maximal inhibitory concentration: 355 nM
The estimate for compound 3 lay 7.0-fold (0.85 log units) above the measured number; the whole stated range lies above it.
By their numbers in this assay, from the lowest: compound 3; then compound 2; then compound 1.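

In this assay, the halogen on this aromatic carbon is not a neutral exchange: fluoro in place of chloro gives a 5.0-fold lower number from compound 2 to compound 3 (0.70 log units; beyond the scatter). The change of a single heavy atom, ortho to a large group, therefore moves the number beyond the scatter, which the earlier step could not show, as it replaced a whole side chain. Set against the cyclohexylsulfanyl group, the ((2-fluorophenyl)sulfanyl)methyl group gives an 18-fold lower number from compound 1 to compound 3 (1.25 log units; beyond the scatter), and nothing at hand bears on the reason for either step.

With only two halogens compared at this place, no trend can be drawn. Going by these compounds, it remains open how bromo, a methoxy group or an amine on the same carbon would compare with fluoro, and whether a longer chain in place of the sulfanylmethyl link would keep the lower number of compound 3.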